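Aryl for tert-butyl on the five-membered ring: compound 4

The compounds below may be only part of what the source reports. "The series", "measured", "known", "first", "only" and "open" are said of these compounds alone.

Measured compounds:
compound 1 `CC(C)n1nc(-c2cc(C(C)(C)C)on2)c2c(N)ncnc21` gives 210 nM
compound 2 `CCCCCCCn1nc(-c2cc(C3CC3)on2)c2c(N)ncnc21` gives 96 nM
compound 3 `Cn1nc(-c2cc(C3CC3)on2)c2c(N)ncnc21` gives 27 nM

In an assay on isolated protein for inhibition of proto-oncogene tyrosine-protein kinase receptor Ret (Homo sapiens), read by radiometric assay and 33P incorporation, in the presence of a further agent that is not named here (a lower number here means a stronger inhibitor, a higher number a weaker inhibitor), compound 1 holds the highest number of the three, and compound 3 the lowest. Going by the values given here, the only single-point step measured so far is a 3.6-fold lower number from compound 2 to compound 3 (0.55 log units; beyond the scatter), which concerns the chain on the aromatic nitrogen and not the position changed here. Compound 4 `CC(C)n1nc(-c2cc(-c3ccc(F)cc3)on2)c2c(N)ncnc21` differs from compound 1 by 4-fluorophenyl in place of tert-butyl on an aromatic carbon. Among the compounds with values here, no measured step touches this position, so nothing points to a direction beyond the scatter. Compound 4 is therefore expected near 160 nM, within 50 nM to 500 nM. That estimate means an expected step of a 1.3-fold lower number from compound 1 to compound 4 (0.12 log units; within the scatter).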

Compound 4, half-maximal inhibitory concentration: 150 nM
Estimate against measurement, compound 4: 1.1-fold (0.03 log units) above; measured number inside the range.
By their numbers in this assay, from the lowest: compound 3; then compounds 2, 4 and 1 (each within the scatter of the next, the first and the last beyond it).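

In this assay, going by these compounds alone, the first measured step at this position, on the aromatic carbon next to the ring oxygen, is a 1.4-fold lower number from compound 1 to compound 4 (0.15 log units; within the scatter), so tert-butyl and 4-fluorophenyl cannot be told apart here. At this position, a six-membered aromatic ring of carbon only thus reads the same as a ringless group of fewer heavy atoms. No available evidence bears on this result. The compounds shown leave open whether an amine or a carboxylic acid on the phenyl ring would keep this reading. They also leave open how cyclopropyl at this position compares with tert-butyl and 4-fluorophenyl on the same core.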